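Chloro for methyl on the pyridine of two quinolin-2-amines

A few compounds are considered here, and "the series" means these few. Any claim that something is new, unique, unknown or untested is made for them only; others in the source may bear on it.

Compound 1 `Cc1ccnc(Nc2ccc3ccccc3n2)c1` is the simplest member of the set. In a functional assay on PC-3 cells (Homo sapiens) for antiproliferative activity, read by MTT assay, with a stated time of 96 h (on this read-out lower numbers stand for stronger inhibition of growth and higher numbers for weaker inhibition of growth), compound 1 gives 26700 nM. Compound 2 `Clc1ccnc(Nc2ccc3ccccc3n2)c1` carries the change chloro in place of methyl on an aromatic carbon on the same core. In this assay compound 2 reaches only a limit of the assay, > 30000 nM. The step of an at least 1.1-fold higher number from compound 1 to compound 2 (0.05 log units; that floor lies within the scatter) is therefore known only as a floor, and that floor lies within the scatter, so no order between compound 1 and compound 2 can be read from it.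

Compound 3 `COc1ccc(Cl)c2ccc(Nc3cc(C)ccn3)nc12` belongs to a second core; how it differs from the core of compound 1 is not broken down here. In this assay compound 3 also returns only a limit of the assay, > 30000 nM. Of the three values shown, two sit at this limit (the limit of > 30000 nM in this assay, at which 2 of the 3 values shown sit).

Compound 4 `COc1ccc(Cl)c2ccc(Nc3cc(Cl)ccn3)nc12` is the counterpart of compound 3 with the change (chloro in place of methyl on an aromatic carbon). The place of this change is described in the same words as for the pair of compound 1 and compound 2, so it is the same change made on the second core.

For compound 4 the step that the limit leaves unreadable from compound 3 to compound 4 is expected to be small or unresolved. That expectation rests on compound 3 sitting at the limit > 30000 nM and on the at most modest step an at least 1.1-fold higher number from compound 1 to compound 2 (0.05 log units; that floor lies within the scatter) seen on the first core. In this assay compound 4 is therefore expected to give about 60000 nM, between 30000 nM and 200000 nM, most likely reported only as a limit.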

Compound 4, concentration for 50% growth inhibition: > 30000 nM
Compound 4: only a limit was reported; the forecaster's own chance of this, stated with the estimate: 85%; the middle value is on the limit's open side.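

In this assay compound 4 gives > 30000 nM, a limit of the assay. Compound 3 also stands at a limit, so no step from compound 3 to compound 4 can be read: the limit of > 30000 nM in this assay, at which 3 of the 4 values shown sit.

The compounds shown leave open whether chloro in place of methyl on an aromatic carbon shifts growth inhibition on either core, and where the true values of compound 2, compound 3 and compound 4 lie.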